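The compounds below may be only part of what the source reports. "The series", "measured", "known", "first", "only" and "open" are said of these compounds alone.

In a functional assay on the whole organism for inhibition, with Nicotiana tabacum as the target (on this read-out higher numbers stand for weaker inhibition and lower numbers for stronger inhibition), compound 1 `Cc1ccc(Nc2[nH]c(C)nc3nccc2-3)cc1` gives 759000000 nM, compound 2 `CCOc1ccc(Nc2[nH]c(C)nc3nccc2-3)cc1` gives 347000000 nM and compound 3 `CCCc1ccc(Nc2[nH]c(C)nc3nccc2-3)cc1` gives 105000000 nM. Compound 3 is the strongest inhibitor of the three: a 7.2-fold lower number from compound 1 to compound 3 (0.86 log units; beyond the scatter) and a 3.3-fold lower number from compound 2 to compound 3 (0.52 log units; beyond the scatter), with a 2.2-fold lower number from compound 1 to compound 2 (0.34 log units; beyond the scatter) as the smaller move. Compound 4 `Cc1nc2nccc-2c(Nc2ccc(C(C)C)cc2)[nH]1` differs from compound 3 by isopropyl in place of propyl on an aromatic carbon. Among the compounds with values here, none of the measured steps alters the branching of a group in this way; each exchanges or lengthens the group as a whole, so the improvement seen on reaching propyl gives no direct guide to rearranging it. Accordingly no step beyond the scatter is expected in this assay, and the estimated step is a 1.2-fold higher number from compound 3 to compound 4 (0.09 log units; within the scatter). For compound 4 the expected value is 130000000 nM, within 45000000 nM to 400000000 nM.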

Compound 4, half-maximal inhibitory concentration: 45700000 nM
Compound 4: the middle estimate sits 2.8-fold (0.45 log units) above what was measured; the measured number falls inside the stated range.
By their numbers in this assay, from the lowest: compound 4; then compound 3; then compound 2; then compound 1.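

Rearranging the same atoms from propyl to isopropyl on the aromatic carbon para to a large group still moves the number in this assay (a 2.3-fold lower number from compound 3 to compound 4 (0.36 log units; beyond the scatter)), so the arrangement of the group matters here, not only its atom count. Isopropyl also leads the other groups (a 7.6-fold lower number from compound 2 to compound 4 (0.88 log units; beyond the scatter); a 17-fold lower number from compound 1 to compound 4 (1.22 log units; beyond the scatter)), which makes compound 4 the strongest inhibitor of the four. No measurement bears on what underlies this gain. Open, from the compounds shown here alone, is whether tert-butyl or cyclopropyl at this position lowers the number further. Also open, going by these compounds, is how an amine or a carboxylic acid would read there.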